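Working notes: from compound 3 to compound 4

The source may report more compounds than this note shows. Statements on the series, on what has been measured and on what is new or still open speak of the compounds shown alone.

Compound 1 `CCCCCCCc1ccc(NS(=O)(=O)c2ccc(N3CCNC3=O)cc2)cc1`: > 1000 nM
Compound 2 `O=C1NCCN1c1ccc(S(=O)(=O)Nc2ccccc2)cc1`: 200 nM
Compound 3 `O=C1NCCN1c1ccc(S(=O)(=O)Nc2ccc(F)c(F)c2)cc1`: 220 nM

The value for compound 1 is > 1000 nM, which is a limit. In a functional assay on M21 cells (Homo sapiens) for antiproliferative activity, read by sulforhodamine B assay, with a stated time of 48 h (on this read-out higher numbers stand for weaker inhibition and lower numbers for stronger inhibition), compound 3 gives 220 nM, within the scatter of compound 2 at 200 nM.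

Compound 4 `O=C1NCCN1c1ccc(S(=O)(=O)Nc2ccc(Cl)cc2)cc1` follows from compound 3 by one change: 4-chlorophenyl in place of 3,4-difluorophenyl on a sulfonamide nitrogen. The closest evidence is at the same sulfonamide nitrogen, a 1.1-fold higher number from compound 2 to compound 3 (0.04 log units; within the scatter). The other measured step, an at least 5.0-fold lower number from compound 1 to compound 2 (0.69 log units; beyond the scatter), concerns heptyl on an aromatic carbon and bears on this change only weakly. The expected step is a 1.0-fold lower number from compound 3 to compound 4 (0.02 log units; within the scatter), so none beyond the scatter is anticipated. Compound 4 is estimated at 210 nM, with an expected range of 100 nM to 450 nM.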

Compound 4, half-maximal inhibitory concentration: 90 nM
Estimate against measurement, compound 4: 2.3-fold (0.37 log units) above, outside the stated range (below it).
By their numbers in this assay, from the lowest: compound 4; then compounds 2 and 3 (each within the scatter of the next). At a limit, above all of these: compound 1.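

In this assay, chloro in place of hydrogen on an aromatic carbon gives a 2.2-fold lower number from compound 2 to compound 4 (0.35 log units; beyond the scatter), and 4-chlorophenyl in place of 3,4-difluorophenyl gives a 2.4-fold lower number from compound 3 to compound 4 (0.39 log units; beyond the scatter). The aryl group on the sulfonamide nitrogen can therefore move this read-out beyond the scatter, which compound 2 and compound 3 did not show. Chloro in place of heptyl gives an at least 11-fold lower number from compound 1 to compound 4 (1.04 log units; beyond the scatter), a step that rests on a limit for compound 1 and not on a number: the limit of > 1000 nM in this assay, at which 1 of the 4 values shown sits.

Still open, from the compounds shown here alone, is whether a methoxy group, an amine or a carboxylic acid in place of chloro on that aromatic carbon would keep this lower number. Also open, going by these compounds, is how a chain shorter than heptyl would read.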